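The compounds below may be only part of what the source reports. "The series", "measured", "known", "first", "only" and "open" are said of these compounds alone.

Measured compounds:
compound 1 `CCCCCCCCC(=O)N1c2ccccc2CCC1C(=O)Nc1ccccc1C(F)(F)F`: 4320 nM
compound 2 `COc1ccc(NC(=O)C2CCc3ccccc3N2)cc1`: 56900 nM
compound 3 `CCCCCCCCC(=O)N1c2ccccc2CCC1C(=O)Nc1ccccc1O`: 45200 nM

In a functional assay on PC-3 cells (Homo sapiens) for cytotoxicity, read by sulforhodamine B assay, with a stated time of 72 h (on this read-out higher numbers stand for weaker inhibition of growth and lower numbers for stronger inhibition of growth), compound 1 has the lowest of the three numbers. The step of a 10-fold higher number from compound 1 to compound 3 (1.02 log units; beyond the scatter) was large, and compound 2 gives a still higher value than compound 1. Compound 4 `O=C(Nc1ccccc1C(F)(F)F)C1CCc2ccccc2N1C(=O)c1ccccc1Cl` differs from compound 1 by 2-chlorophenyl in place of octyl on a carbonyl carbon. Within the data shown here, no measured pair changes this part of the molecule: the only measured step alters the group on the anilide ring, so nothing measured speaks directly to swapping an octyl chain for a 2-chlorophenyl ring here. The expectation is therefore uncertain, and compound 4 is estimated to give a somewhat higher number than compound 1, a step of a 2.1-fold higher number from compound 1 to compound 4 (0.32 log units; beyond the scatter), with a wide range from 2000 nM to 40000 nM around an estimate of 9000 nM.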

Compound 4, concentration for 50% growth inhibition: 5140 nM
The estimate for compound 4 lay 1.8-fold (0.24 log units) above the measured number, and the stated range covers the measured number.
By their numbers in this assay, from the lowest: compounds 1 and 4 (each within the scatter of the next); then compounds 3 and 2 (each within the scatter of the next).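

Among these compounds, no earlier pair touched this carbonyl carbon, and in this assay the change from octyl to 2-chlorophenyl gives a 1.2-fold higher number from compound 1 to compound 4 (0.08 log units; within the scatter). With the trifluoromethyl group kept, a chain and an aromatic ring at this position therefore give numbers that cannot be told apart on this read-out. Nothing at hand explains this result. As far as these compounds go, whether an amine or a carboxylic acid on this group would be tolerated stays open. So does whether the same swap holds when hydroxy replaces trifluoromethyl.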